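The source may hold more compounds than are shown below. What is called first, only, known or untested is meant among the compounds shown, and "the series" means these compounds.

Measured so far:
compound 1, `Cc1cccc(-c2nc(CNc3ccc(C(=O)NO)cc3)n(-c3ccccc3)n2)c1`: 64.1%
compound 2, `Cc1cccc(-n2nc(-c3ccccc3)nc2CNc2ccc(C(=O)NO)cc2)c1`: 66%
compound 3, `CNC(=O)c1ccc(NCc2nc(-c3ccccc3)nn2-c2ccccc2)cc1`: -3.6%

Of the compounds shown here, three built on the same core have been measured in an assay on Sf9 cells for inhibition of protein deacetylase HDAC6 (Homo sapiens), read by fluorescence, with a stated time of 40 min, tested at 100 nM; on this read-out higher numbers stand for more inhibition at the one concentration tested (going by the name of the read-out) and lower numbers for less inhibition. Compound 1 gives 64.1%, the second highest of the three numbers. Its nearest neighbour is compound 2, which in this assay gives 66%; the two values lie within the scatter of each other, so no order between compound 1 and compound 2 can be read from them. The furthest is compound 3, which in this assay gives -3.6%, a number well beyond the scatter below compound 1. Going by the values given here, no step between any pair of the measured compounds is counted, so only the values themselves can be compared.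

The next compound, compound 4, `O=C(NO)c1ccc(NCc2nc(-c3ccc(Cl)c(Cl)c3)nn2-c2ccccc2)cc1`, has not been measured. It differs from compound 1 in one place: 3,4-dichlorophenyl in place of 3-methylphenyl on an aromatic carbon. Among the compounds with values here, since no counted step among the measured compounds involves this part of the molecule, there is nothing to anchor the size of the change. The expectation is therefore that the step of a number 0.9 percentage points higher from compound 1 to compound 4 (within the scatter) stays within the scatter, in no set direction. On this basis compound 4 is expected to give about 65% in this assay, estimated to fall between 45% and 82%.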

Compound 4, a percentage reported as inhibition, at one concentration (the size of the read-out at that concentration, not a potency): 34.5%
Estimate against measurement, compound 4: 30.5 percentage points above; measured number below the stated range.
By their numbers in this assay, from the lowest: compound 3; then compound 4; then compounds 1 and 2 (each within the scatter of the next).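

In this assay, going by these compounds alone, the exchange of 3-methylphenyl for 3,4-dichlorophenyl on the aromatic carbon between two ring nitrogen atoms gives a number 29.6 percentage points lower from compound 1 to compound 4 (beyond the scatter) and is the first counted step at this position, showing that the read-out is not indifferent to the group held there. The change is small by count: the six-membered aromatic ring stays, hydrogen-bond donors, acceptors and net charge do not change, and the heavy-atom count differs by one. Nothing measured here accounts for the step.

The compounds shown leave open whether the step follows from losing the methyl group or from gaining either chlorine, as neither a plain phenyl group nor a ring with a single chlorine, such as 4-chlorophenyl, stands at this position among them. Also open, going by these compounds, is how the read-out would respond to a methoxy group, an amine or a carboxylic acid on this same ring.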